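A few compounds are considered here, and "the series" means these few. Any claim that something is new, unique, unknown or untested is made for them only; others in the source may bear on it.

The measured compounds:
compound 1, `Clc1ccc2c(NCCCNc3nccc(Nc4ccccc4)n3)ccnc2c1`, giving 12800 nM
compound 2, `Fc1ccc(Nc2ccnc(NCCCNc3ccnc4cc(Cl)ccc34)n2)cc1`, giving 13700 nM
compound 3, `Clc1ccc2c(NCCCCNc3nccc(Nc4ccccc4)n3)ccnc2c1`, giving 14300 nM

All three numbers come from an ADME assay on Vero cells (Chlorocebus sabaeus) for cytotoxicity, read by neutral red uptake, with a stated time of 72 h; on this read-out lower numbers stand for stronger inhibition and higher numbers for weaker inhibition. In this assay compound 1 gives 12800 nM and compound 2 gives 13700 nM. The change from compound 1 to compound 2 is fluoro in place of hydrogen on an aromatic carbon, and it made a 1.1-fold higher number from compound 1 to compound 2 (0.03 log units; within the scatter). Compound 3 gives 14300 nM in this assay; it shares most of its structure with compound 1, but the difference between the two cores is not broken down here. The three values lie so close together that none of them can be set apart from the others.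

Compound 4, `Fc1ccc(Nc2ccnc(NCCCCNc3ccnc4cc(Cl)ccc34)n2)cc1`, has not been measured in this assay. Among the measured compounds shown here, it differs from compound 3 by fluoro in place of hydrogen on an aromatic carbon, which is the same change as the one from compound 1 to compound 2, placed in the same way. Because a 1.1-fold higher number from compound 1 to compound 2 (0.03 log units; within the scatter) was within the scatter, the same change is expected to leave the number for compound 4 close to that of compound 3. The expected step is a 1.0-fold higher number from compound 3 to compound 4 (0.02 log units; within the scatter), an estimate that rests on compound 1 and compound 2 alone, as the change has been seen only once among the measured compounds. Compound 4 is therefore expected to give 15000 nM in this assay, with an estimated range from 8500 nM to 27000 nM.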

Compound 4, half-maximal inhibitory concentration: "not active" (no number reported)
Compound 4 has no reported number here; the estimate stays without a comparison.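

In this assay, among the compounds shown here, compound 4 is reported only as "not active", without a number, and no step from compound 3 to compound 4 can be read from this result. The compounds shown leave open whether fluoro in place of hydrogen changes the number for compound 3 at all. No supporting measurement is available that bears on this result.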